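This account rests on a few compounds, and the source may have more. Where it says the series, first, only, none or still open, it means among the compounds named here.

Measured so far in a functional assay on DU-145 cells (Homo sapiens) for cytotoxicity, read by MTT assay, with a stated time of 48 h; on this read-out lower numbers stand for stronger inhibition and higher numbers for weaker inhibition:
Compound 1 `COc1ccc(-c2nc3ccccn3c2C(=O)/C=C\Nc2cc(OC)cc(OC)c2)cc1`: 6260 nM
Compound 2 `COc1ccc(-c2nc3ccccn3c2C(=O)/C=C\Nc2ccc3[nH]ccc3c2)cc1`: 11300 nM

Only these two numbers are available, and they cannot be told apart. Within the data shown here, compound 2 stands at 11300 nM, and the comparison with its only neighbour reads a 1.8-fold higher number from compound 1 to compound 2 (0.26 log units; within the scatter).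

Compound 3 `COc1ccc(-c2nc3ccccn3c2C(=O)/C=C\Nc2ccc3cc[nH]c3c2)cc1` has the same atoms as compound 2, joined differently: 1H-indol-6-yl in place of 1H-indol-5-yl on an amine nitrogen. The indole stays on the amine nitrogen and only its point of attachment moves.

Among the measured compounds shown here, no measured step shows such a move. The closest evidence is a 1.8-fold higher number from compound 1 to compound 2 (0.26 log units; within the scatter), a replacement of the whole 3,5-dimethoxyphenyl group at that same place. This gives no reason to expect a real shift in this assay, so no direction is predicted beyond the scatter.

The expected result is a 1.1-fold lower number from compound 2 to compound 3 (0.05 log units; within the scatter). For compound 3 the estimate is 10000 nM, with an expected range of 4000 nM to 25000 nM.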

Compound 3, half-maximal inhibitory concentration: 10700 nM
Beside the measured number, compound 3's estimate is 1.1-fold (0.03 log units) below it; the measured number falls inside the stated range.
By their numbers in this assay, from the lowest: compounds 1, 3 and 2 (each within the scatter of the next).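

Moving the attachment point of the indole on the amine nitrogen, from 1H-indol-5-yl to 1H-indol-6-yl, gives a 1.1-fold lower number from compound 2 to compound 3 (0.02 log units; within the scatter) in this assay, so this change has no readable effect. Putting 1H-indol-6-yl in place of 3,5-dimethoxyphenyl gives a 1.7-fold higher number from compound 1 to compound 3 (0.23 log units; within the scatter), so neither indole can be told apart from the 3,5-dimethoxyphenyl group at this place. Nothing available here explains why these groups give such similar numbers.

Still open, on these data alone, is whether a different kind of group on this amine nitrogen, such as a pyridine ring, a phenyl ring carrying a carboxylic acid, or an indole with a methyl group on its ring nitrogen, would move the number beyond the scatter. The compounds also leave open whether changes elsewhere on the shared core would matter more than changes at this place.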